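Pyrazine amides to a carboxylic acid: solubility outlook

A few compounds are considered here, and "the series" means these few. Any claim that something is new, unique, unknown or untested is made for them only; others in the source may bear on it.

Two aminopyrazines have been measured in a physicochemical assay for solubility, read by HPLC, using the shake flask method, with a stated time of 2 h, at pH 2; on this read-out higher numbers stand for higher solubility and lower numbers for lower solubility. Compound 1 `CS(=O)(=O)c1ccc(-c2cnc(N)c(-c3ccc(N)nc3)n2)cc1` gives 206000 nM in this assay. Compound 2 `Nc1ncc(-c2ccc(C(=O)N3CCC(N)C3)cc2)nc1-c1ccc(C(F)(F)F)cc1` gives 165000 nM in this assay, and the gap between compound 2 and compound 1 lies within the usual scatter, so the two compounds cannot be set in order on solubility; compound 2 simply sits at the lower of the two readings by a margin that means nothing.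

The next compound is compound 3 `Nc1ncc(-c2ccc(C(=O)O)cc2)nc1-c1ccc(C(F)(F)F)cc1`, which has not yet been measured in this assay. It differs from compound 2 in one place: hydroxy in place of 3-aminopyrrolidin-1-yl on a carbonyl carbon. The ring and one hydrogen-bond acceptor that compound 2 carries in this position are gone, and a single hydroxy stands on the carbonyl carbon instead.

Among the measured compounds shown here, no step between two measured compounds is available to calibrate a change of this kind, so the forecast rests on compound 2 alone. A drop beyond the scatter is expected, amounting to a 5.5-fold lower number from compound 2 to compound 3 (0.74 log units; beyond the scatter). Compound 3 is therefore estimated at 30000 nM in this assay, with a plausible range from 7000 nM to 120000 nM.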

Compound 3, solubility: < 5000 nM
Compound 3: a limit, no number; the forecaster's own chance of this, stated with the estimate: 5%; at least 6.0-fold (0.77 log units) between middle value and limit.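

Among the compounds shown here, the change from (3-aminopyrrolidin-1-yl)carbonyl to carboxy provides the first step that can be read in this assay, and it is large: an at least 33-fold lower number from compound 2 to compound 3 (1.51 log units; beyond the scatter). Compound 3 gives < 5000 nM, and this reading is a limit of the assay, not a number. The group on the carbonyl carbon is thus shown to be one whose exchange can move this read-out well beyond the scatter, something the earlier compounds could not show, although the full size of the step stays open: the limit of < 5000 nM in this assay, at which 1 of the 3 values shown sits.

The compounds shown leave open which part of the 3-aminopyrrolidin-1-yl group matters, since the ring and its amine leave together in this one step; a pyrrolidin-1-yl amide without the amine, or an open-chain aminoethyl amide, would separate the two. They also leave open whether the step depends on the free carboxy group itself, which a methyl ester or a primary amide on the same carbonyl carbon could address, and they give no measured property that would explain the step.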